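Same-atom swap from compound 3 to compound 4

The source may hold more compounds than are shown below. What is called first, only, known or untested is meant among the compounds shown, and "the series" means these compounds.

Measured so far in a functional assay for inhibition, with Homo sapiens as the target; a higher number here means a weaker inhibitor, a lower number a stronger inhibitor
compound 1 `CC(C)(C)Sc1c(CC(C)(C)C(=O)O)n(Cc2ccc(Cl)cc2)c2ccc(CCc3ccc4ccccc4n3)cc12` gives 4 nM
compound 2 `CC(C)(C)Sc1c(CC(C)(C)C(=O)O)n(Cc2ccc(Cl)cc2)c2ccc(OCc3ccc4cc(F)c(F)cc4n3)cc12` gives 7 nM
compound 3 `CC(C)(C)Sc1c(CC(C)(C)C(=O)O)n(Cc2ccc(Cl)cc2)c2ccc(OCc3ccc4cccnc4n3)cc12` gives 6 nM

The steps of a 1.5-fold higher number from compound 1 to compound 3 (0.18 log units; within the scatter) and a 1.2-fold lower number from compound 2 to compound 3 (0.07 log units; within the scatter) both stay within the scatter, so compound 3 at 6 nM cannot be told apart from the other two compounds. Still unmeasured is compound 4 `CC(C)(C)Sc1c(CC(C)(C)C(=O)O)n(Cc2ccc(Cl)cc2)c2ccc(OCc3ccc4cnccc4n3)cc12` in the same series. The change is a group of 10 heavy atoms (8 carbon, 2 nitrogen; 2 six-membered aromatic rings with 1 hetero atom each) in place of a group of 10 heavy atoms (8 carbon, 2 nitrogen; 2 six-membered aromatic rings with 1 hetero atom each), on a saturated chain carbon bound to an oxygen on an aromatic ring and it lies on a saturated chain carbon bound to an oxygen on an aromatic ring; the two have the same atoms, joined differently.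

Of the measured steps, a 1.2-fold lower number from compound 2 to compound 3 (0.07 log units; within the scatter) is the closer guide, as it exchanges a group at that same place, and a 1.5-fold higher number from compound 1 to compound 3 (0.18 log units; within the scatter) adds that a wider exchange also stayed within the scatter. Among the compounds with values here, no measured step rejoins the same atoms, so this evidence is indirect and the range is kept wide. No step beyond the scatter is expected in this assay and the estimated step of a 1.2-fold higher number from compound 3 to compound 4 (0.07 log units; within the scatter) has no firm direction. For compound 4 the estimated value is 7 nM with an expected range from 3 nM to 16 nM in this series.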

Compound 4, half-maximal inhibitory concentration: 3 nM
The estimate for compound 4 lay 2.3-fold (0.37 log units) above the measured number; the measured number falls inside the stated range.
By their numbers in this assay, from the lowest: compounds 4, 1, 3 and 2 (each within the scatter of the next, the first and the last beyond it).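

In this assay, rejoining the same atoms on a saturated chain carbon bound to an oxygen on an aromatic ring gives a 2.0-fold lower number from compound 3 to compound 4 (0.30 log units; within the scatter), so this change does not separate the pair. Exchange of the fluorine-bearing group at that same place now gives a 2.3-fold lower number from compound 2 to compound 4 (0.37 log units; beyond the scatter), a modest step and the first in the series to pass the scatter, whereas a 1.2-fold lower number from compound 2 to compound 3 (0.07 log units; within the scatter) did not; this position can therefore show a measurable difference, though only between the end members of the series. The wider exchange on an aromatic carbon remains unresolved, with a 1.3-fold lower number from compound 1 to compound 4 (0.12 log units; within the scatter).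

No accompanying measurement accounts for any of these steps. Open, as far as these compounds go, is whether an amine or a methoxy group on the group at this place, or a longer chain at the saturated chain carbon, would stay within the scatter of compound 4 or give a larger step, and whether any other arrangement of the same atoms would separate clearly from compound 3.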